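Swapping a Methoxyphenyl for Bromine on the Sulfonyl Ring

The compounds below may be only part of what the source reports. "The series", "measured", "known", "first", "only" and "open" are said of these compounds alone.

Compound 3 `COc1ccc(-c2ccccc2S(=O)(=O)N2CCC(N3CCC(C)CC3)CC2)cc1` was tested in an ADME assay on HCT-116 cells (Homo sapiens) for cytotoxicity, read by CellTiter-Glo, with a stated time of 72 h; a lower number here means a stronger inhibitor, a higher number a weaker inhibitor. In this assay compound 3 gives only a limit, > 5000 nM. The other measured compounds also stop at limits. Compound 1 `CCc1ccc(S(=O)(=O)N2CCC(N3CCC(C)CC3)CC2)cc1` gives a limit of > 5000 nM in this assay. Compound 2 `CC1CCN(C2CCN(S(=O)(=O)c3cccnc3Cl)CC2)CC1` gives a limit of > 10000 nM. For the measured compounds named here, the single measured step, a step that the two limits leave unreadable from compound 1 to compound 2, cannot be sized, as the limit of > 5000 nM in this assay, at which 2 of the 3 values shown sit, and the limit of > 10000 nM in this assay, at which 1 of the 3 values shown sits, show. Compound 4 `CC1CCN(C2CCN(S(=O)(=O)c3ccccc3Br)CC2)CC1` carries the change (bromo in place of 4-methoxyphenyl on an aromatic carbon). Going by the values given here, no measured step bears on this change, so the expected step is a step that the limit leaves unreadable from compound 3 to compound 4, nothing beyond the scatter. Compound 4 is estimated at 8000 nM, with a range from 3000 nM to 20000 nM, and most likely this assay will again report only a limit.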

Compound 4, half-maximal inhibitory concentration: > 5000 nM
Compound 4 ended at the assay's limit; the forecaster's own chance of this, stated with the estimate: 85%; the middle value does not contradict the limit.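

For the compounds shown here, compound 4 gives only a limit, as do compound 1, compound 2 and compound 3, so no new step to compound 4 can be read. The compounds shown leave open what real potency any of them has in this assay.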